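The source may report more compounds than this note shows. Statements on the series, on what has been measured and on what is new or still open speak of the compounds shown alone.

Measured in a functional assay on RPMI8266 cells (Homo sapiens) for cytotoxicity, read by sulforhodamine B assay, with a stated time of 48 h, tested at 100 nM; a higher number here means a weaker effect of the compound at the concentration tested, a lower number a stronger effect:

Compound 1 `COc1cc(C)cc(-c2nn(CC#N)cc2-c2ccc(-c3cccc(C(C)=O)c3)nc2)c1` gives 96%.
Compound 2 `Cc1cc(O)cc(-c2nn(CC#N)cc2-c2ccnc(-c3ccc(Oc4ccccc4)cc3)c2)c1` gives 88%.
Compound 3 `COc1cc(C)cc(-c2nn(CC#N)cc2-c2ccnc(-c3ccc(N(C)C)cc3)c2)c1` gives 57%.

Compound 3 stands lowest of the three numbers in this assay, and so shows the strongest effect; compound 2 is nearest, beyond the scatter, and compound 1 furthest, also beyond the scatter. Compound 4 `Cc1cc(O)cc(-c2nn(CC#N)cc2-c2ccnc(-c3ccc(N(C)C)cc3)c2)c1` is not yet measured. It differs from compound 3 in one place (hydrogen in place of methyl on an oxygen on an aromatic ring).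

Within the data shown here, no pair of measured compounds differs in only this place, so the size of this change has not been seen on its own. In this assay the step is expected to be small, within the scatter, perhaps slightly upward, and the expected step is a number 6 percentage points higher from compound 3 to compound 4 (within the scatter). Compound 4 is therefore estimated at 63%, with a range from 45% to 82%.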

Compound 4, a percentage reported as activity, at one concentration (the size of the read-out at that concentration, not a potency): 96%
Compound 4: the middle estimate sits 33 percentage points below what was measured, outside the stated range (above it).
By their numbers in this assay, from the lowest: compound 3; then compounds 2, 1 and 4 (each within the scatter of the next).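

In this assay, this pair gives the first view of the oxygen on the aromatic ring: going from methoxy to hydroxy is a large change, a number 39 percentage points higher from compound 3 to compound 4 (beyond the scatter), so the effect of compound 3 depends on that methyl even with dimethylamino present. With hydroxy in place, dimethylamino and phenoxy cannot be told apart, a number 8 percentage points higher from compound 2 to compound 4 (within the scatter), so dimethylamino alone does not preserve the effect. No available measurement explains the large step.

On these data alone, it remains open whether ethoxy or a longer chain on that oxygen, or an amine in place of it, would preserve the effect. Also open, as far as these compounds go, is how phenoxy behaves when methoxy is present.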